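The compounds below may be only part of what the source reports. "The series", "measured", "known", "first", "only" and "open" are said of these compounds alone.

Measured compounds:
- compound 1, `N=C(N)NCCC[C@H](NC(=O)CN(c1nc(Cl)nc2[nH]cnc12)C1CC1)C(=O)OCc1ccccc1`: in a functional assay on the whole organism (Tail, strain ICR) with Mus musculus as the target, in the tail flick test, with a stated time of 90 min, at a dose of 25 umol/kg by the oral route (on this read-out higher numbers stand for a stronger effect at the one dose given and lower numbers for a weaker effect), compound 1 gives 30.4%
- compound 2, `N=C(N)NCCC[C@H](NC(=O)CN(c1ncnc2c1ncn2C1CCCCO1)C1CC1)C(=O)OCc1ccccc1`: in this assay compound 2 gives 61.6%
- compound 3, `CC(C)C[C@H](NC(=O)CN(c1nc(Cl)nc2[nH]cnc12)C1CC1)C(=O)OCc1ccccc1`: in this assay compound 3 gives 15.2%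

Compound 2 stands highest of the three in this assay, with compound 1 nearest and compound 3 furthest, both gaps beyond the scatter. Compound 1 and compound 2 share the side chain and differ in their cores; the difference between the two cores is not broken down here.

One change is seen twice in the series. From compound 1 to compound 3 it is a group of 3 heavy atoms (3 carbon; no ring) in place of a group of 6 heavy atoms (3 carbon, 3 nitrogen; no ring), on a saturated chain carbon, two bonds along the chain from an amide-type nitrogen and a carbonyl carbon and it gave a number 15.2 percentage points lower from compound 1 to compound 3 (beyond the scatter). The same change, (a group of 3 heavy atoms (3 carbon; no ring) in place of a group of 6 heavy atoms (3 carbon, 3 nitrogen; no ring), on a saturated chain carbon, two bonds along the chain from an amide-type nitrogen and a carbonyl carbon), carries the core of compound 2 to the unmeasured compound 4, `CC(C)C[C@H](NC(=O)CN(c1ncnc2c1ncn2C1CCCCO1)C1CC1)C(=O)OCc1ccccc1`. The place of the change is the same in both pairs, so this is the same change on the two cores.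

Within the data shown here, with only one measured instance, the expectation for compound 4 rests on a single step. A drop of about the same size is expected from compound 2 to compound 4 in this assay, a number 21.6 percentage points lower from compound 2 to compound 4 (beyond the scatter), because the same change gave a number 15.2 percentage points lower from compound 1 to compound 3 (beyond the scatter). Since compound 2 starts from a higher number than compound 1 did, the drop in absolute terms could be somewhat larger, and the range is set wide accordingly. Compound 4 is therefore estimated at 40%, between 22% and 58%.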

Compound 4, a percentage reported as activity, at one dose (the size of the read-out at that dose, not a potency): 28.2%
Compound 4: the middle estimate sits 11.8 percentage points above what was measured; the range from low to high includes it.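

In this assay, isopropyl in place of the group of 6 heavy atoms, on a saturated chain carbon, two bonds along the chain from an amide-type nitrogen and a carbonyl carbon, gives a number 33.4 percentage points lower from compound 2 to compound 4 (beyond the scatter). The change lowers the read-out on both cores, so its direction carries over in these two pairs, but its size does not: the same change on two cores in this assay, a number 15.2 percentage points lower (beyond the scatter) from compound 1 to compound 3 and a number 33.4 percentage points lower (beyond the scatter) from compound 2 to compound 4, 18.2 percentage points apart, beyond the scatter of two such steps

These two pairs do not show which feature of the cores goes with the difference in size, nor how the change would behave on a further core. The group that leaves also differs from isopropyl in heavy atoms, nitrogen content, double bond and hydrogen-bond donors and acceptors all at once, so the pairs do not separate these features from one another.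

The compounds shown leave open how a simple amine, a carboxylic acid or a longer alkyl chain would read on that saturated chain carbon, on either core. They also leave open how the two cores compare at other doses and times, since each compound here has a single read-out at one dose and one time.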